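Swapping the Ketone Aryl Group for a Furan Ring

The compounds below may be only part of what the source reports. "The series", "measured", "known", "first", "only" and "open" are said of these compounds alone.

Two close analogues sharing one core have been tested in a functional assay on HepG2 cells (Homo sapiens) for cytotoxicity, read by MTT assay, with a stated time of 48 h; a higher number here means a weaker inhibitor, a lower number a stronger inhibitor. Compound 1 (`COc1cc(-c2nnc3n2NC(c2ccco2)C(C(=O)c2ccc(C(F)(F)F)cc2)S3)cc(OC)c1OC`) carries a 4-(trifluoromethyl)phenyl on a carbonyl carbon. In this assay compound 1 gives > 100000 nM, a limit of the assay rather than a number. Compound 2 (`COc1cccc(C(=O)C2Sc3nnc(-c4cc(OC)c(OC)c(OC)c4)n3NC2c2ccco2)c1`) carries a 3-methoxyphenyl on that carbonyl carbon. In this assay compound 2 gives > 100000 nM, which is again a limit and not a number. The step that the two limits leave unreadable from compound 1 to compound 2 cannot be read, since the limit of > 100000 nM in this assay, at which 2 of the 2 values shown sit, shows both values sitting at the limit. For the measured compounds named here, compound 2 thus stands at the limit, with nothing among the measured values placing it higher or lower than its partner.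

Compound 3 (`COc1cc(-c2nnc3n2NC(c2ccco2)C(C(=O)c2ccco2)S3)cc(OC)c1OC`) differs from compound 2 by furan-2-yl in place of 3-methoxyphenyl on a carbonyl carbon. Going by the values given here, the only measured step, that from compound 1 to compound 2, concerns the same carbonyl carbon but has no readable size, so no direction can be drawn from it. With both measured values at the limit, compound 3 is expected to remain there as well, the step that the limit leaves unreadable from compound 2 to compound 3 being an estimate without measured support. The estimate for compound 3 is 150000 nM, with a range from 50000 nM to 500000 nM.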

Compound 3, half-maximal inhibitory concentration: > 100000 nM
Compound 3: a limit, no number (the forecaster's own chance of this, stated with the estimate: 85%); the middle value is on the limit's open side.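

In this assay compound 3 gives > 100000 nM and this is again a limit of the assay, not a number. The steps among compound 1, compound 2 and compound 3 therefore cannot be read: the limit of > 100000 nM in this assay, at which 3 of the 3 values shown sit. On these data alone, whether the group on the carbonyl carbon changes the result at all stays open, with no number from any of the three compounds.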